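Amide aryl variation: from compound 2 to compound 3

A few compounds are considered here, and "the series" means these few. Any claim that something is new, unique, unknown or untested is made for them only; others in the source may bear on it.

Compound 1 `O=C(CN1CCC(c2cccc[n+]2[O-])CC1)Nc1cccc(F)c1` and compound 2 `O=C(CN1CCC(c2cccc[n+]2[O-])CC1)Nc1cc(Cl)cc(Cl)c1` share one core and differ only in the group on the amide-type nitrogen. In a functional assay on HEK293 cells for agonist activity at D(4) dopamine receptor (Homo sapiens), read by FLIPR (a lower number here means a smaller maximal response, a higher number a larger maximal response), compound 1 gives 70%, and compound 2 gives 68%. Among the compounds with values here, the single measured step, a number 2 percentage points lower from compound 1 to compound 2 (within the scatter), lies within the scatter. Compound 2 therefore stands at the lower of the two numbers, but the gap to compound 1 is within the scatter, so no order between the two can be read from it.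

Compound 3 `Cc1cc(F)ccc1NC(=O)CN1CCC(c2cccc[n+]2[O-])CC1` has not yet been measured in this assay. The change from compound 2 is 4-fluoro-2-methylphenyl in place of 3,5-dichlorophenyl on an amide-type nitrogen. Within the data shown here, the only step that bears on it is a number 2 percentage points lower from compound 1 to compound 2 (within the scatter), which shows that putting 3,5-dichlorophenyl in place of 3-fluorophenyl on the amide-type nitrogen left the maximal response within the scatter. Among the measured compounds shown here, no step involving 4-fluoro-2-methylphenyl exists, so the expectation rests on that one flat step alone. For compound 3 the step is therefore expected to be a number 1 percentage points higher from compound 2 to compound 3 (within the scatter), with no movement beyond the scatter. Compound 3 is estimated at 69%, within a range of 55% to 82%.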

Compound 3, largest response reached (reported as efficacy), in percent of the reference or control that the assay uses: 84%
Compound 3: the middle estimate sits 15 percentage points below what was measured; the measured number lies above the stated range.
By their numbers in this assay, from the lowest: compounds 2 and 1 (each within the scatter of the next); then compound 3.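

The position on the amide-type nitrogen is not flat after all: in this assay the maximal response changes by (a number 16 percentage points higher from compound 2 to compound 3 (beyond the scatter)) and by (a number 14 percentage points higher from compound 1 to compound 3 (beyond the scatter)), so 4-fluoro-2-methylphenyl separates compound 3 from both earlier aryl groups, while those two remain within the scatter of each other. The change from 3,5-dichlorophenyl keeps the same count of heavy atoms and the same six-membered aromatic ring of carbon only, and it still moves the response beyond the scatter, so that count alone does not set the read-out across these three compounds. Nothing measured on these compounds accounts for the rise.

The compounds shown leave open whether the methyl or the fluorine of 4-fluoro-2-methylphenyl carries the higher response, or whether the two work only together, since compound 3 differs from each earlier compound in more than one substituent on the aryl ring. They also leave open how the response behaves with an unsubstituted phenyl or a cyclohexyl group on the amide-type nitrogen, and whether the rise seen with compound 3 extends to any other aryl group.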